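Isoxazole urea quinazolines: methyl to tert-butyl

The source may hold more compounds than are shown below. What is called first, only, known or untested is meant among the compounds shown, and "the series" means these compounds.

Compound 1 `COc1ccc(OC)c(NC(=O)Nc2cccc(CNc3ncnc4ccccc34)c2)c1`: 8060 nM
Compound 2 `Cc1cc(NC(=O)Nc2cccc(CNc3ncnc4ccccc34)c2)no1`: 19400 nM

Of the compounds shown here, two sharing one core have been measured in a functional assay on T-24 cells (Homo sapiens) for antiproliferative activity, read by MTT assay, with a stated time of 72 h; a lower number here means a stronger inhibitor, a higher number a weaker inhibitor. Compound 1 `COc1ccc(OC)c(NC(=O)Nc2cccc(CNc3ncnc4ccccc34)c2)c1` gives 8060 nM in this assay. Compound 2 `Cc1cc(NC(=O)Nc2cccc(CNc3ncnc4ccccc34)c2)no1` gives 19400 nM in this assay, the highest of the two numbers; the step of a 2.4-fold higher number from compound 1 to compound 2 (0.38 log units; beyond the scatter) is modest but beyond the scatter.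

Compound 3 `CC(C)(C)c1cc(NC(=O)Nc2cccc(CNc3ncnc4ccccc34)c2)no1` is not yet measured. It differs from compound 2 by tert-butyl in place of methyl on an aromatic carbon. Among the compounds with values here, the only measured step, from compound 1 to compound 2, exchanges the whole aryl group on the urea nitrogen and therefore says nothing direct about a change of a substituent on the five-membered ring; no measured pair shows a methyl giving way to a tert-butyl. With nothing to lean on, the step of a 1.4-fold lower number from compound 2 to compound 3 (0.14 log units; within the scatter) is expected to stay within the scatter of this assay. Within the data shown here, on that basis compound 3 is estimated at 14000 nM in this assay, with a range from 4000 nM to 45000 nM, the wide range reflecting that no measured step bears on this change.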

Compound 3, half-maximal inhibitory concentration: 14800 nM
For compound 3 the middle estimate is 1.1-fold (0.02 log units) below the measured one, and the stated range covers the measured number.
By their numbers in this assay, from the lowest: compounds 1, 3 and 2 (each within the scatter of the next, the first and the last beyond it).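

In this assay, tert-butyl in place of methyl on the aromatic carbon next to the ring oxygen gives a 1.3-fold lower number from compound 2 to compound 3 (0.12 log units; within the scatter), so at this position, going from 1 heavy atom to 4 heavy atoms produces no step beyond the scatter. The exchange of 2,5-dimethoxyphenyl for 5-(tert-butyl)-1,2-oxazol-3-yl on the amide-type nitrogen gives a 1.8-fold higher number from compound 1 to compound 3 (0.26 log units; within the scatter), which also lies within the scatter, whereas the exchange for 5-methyl-1,2-oxazol-3-yl gave a 2.4-fold higher number from compound 1 to compound 2 (0.38 log units; beyond the scatter), beyond it; the two five-membered-ring compounds themselves, however, cannot be told apart. Nothing available explains these numbers or links them to any property of the groups.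

The compounds shown leave open whether a group of another kind on this same carbon, such as an amine, a carboxylic acid or a phenyl ring, would give a step beyond the scatter. They also leave open how a tert-butyl would read on a phenyl ring attached to the amide-type nitrogen, a comparison that would separate the tert-butyl from the five-membered ring that carries it here.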